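From 3-Methoxyphenyl to tert-Butyl on the Core Nitrogen

This account rests on a few compounds, and the source may have more. Where it says the series, first, only, none or still open, it means among the compounds named here.

Within the data shown here, compound 1 `COc1cccc(-n2cnc3cc(C(=O)N4CCCCC4)ccc32)c1` gives 19 nM in an assay on isolated protein for inhibition of 15-hydroxyprostaglandin dehydrogenase [NAD(+)] (Homo sapiens), read by fluorescence, with a stated time of 15 min (a higher number here means a weaker inhibitor, a lower number a stronger inhibitor), the lower of the two numbers measured so far. Compound 2 `O=C(c1ccc2c(c1)ncn2-c1cccc(C(F)(F)F)c1)N1CCCCC1` gives 48 nM in this assay, and the step from compound 1 to compound 2 is a 2.5-fold higher number from compound 1 to compound 2 (0.40 log units; beyond the scatter). Compound 3 `CC(C)(C)n1cnc2cc(C(=O)N3CCCCC3)ccc21` differs from compound 1 by tert-butyl in place of 3-methoxyphenyl on an aromatic nitrogen. Among the measured compounds shown here, no measured step removes the whole ring from this nitrogen; the one known step only exchanges a group on that ring, so it bears little on this change. Weaker inhibition is nonetheless expected, and compound 3 is estimated at 250 nM, within 40 nM to 1500 nM. That expectation corresponds to a step of a 13-fold higher number from compound 1 to compound 3 (1.12 log units; beyond the scatter).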

Compound 3, half-maximal inhibitory concentration: 34 nM
Compound 3: middle estimate off by 7.4-fold (0.87 log units), on the high side, outside the stated range (below it).
By their numbers in this assay, from the lowest: compounds 1, 3 and 2 (each within the scatter of the next, the first and the last beyond it).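

Putting tert-butyl in place of 3-methoxyphenyl on this aromatic nitrogen gives a 1.8-fold higher number from compound 1 to compound 3 (0.25 log units; within the scatter) in this assay even though the six-membered aromatic ring is lost. For this pair, then, inhibition at this level does not depend on an aromatic ring or a hydrogen-bond acceptor in this group. No measurement available here accounts for this result. From the compounds shown here alone, whether a much smaller group, such as methyl, is also tolerated on this nitrogen remains open. So does the effect of a group carrying an amine or a carboxylic acid.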